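The source may hold more compounds than are shown below. What is called first, only, known or untested is meant among the compounds shown, and "the series" means these compounds.

Values in a functional assay on WHCO1 cells (Homo sapiens) for cytotoxicity, read by MTT assay, with a stated time of 24 h (a higher number here means a weaker inhibitor, a lower number a stronger inhibitor), for the series:
compound 1 `CC(C)=CC(O)C1=CC(=O)c2ccccc2C1=O` gives 5200 nM
compound 2 `C=CC(O)C1=CC(=O)c2ccccc2C1=O` gives 4300 nM
compound 3 `O=C1C=C(C(O)c2ccc(Cl)cc2)C(=O)c2ccccc21` gives 3000 nM

Compound 3 (3000 nM) is not separated from the other two compounds. The steps of a 1.7-fold lower number from compound 1 to compound 3 (0.24 log units; within the scatter) and a 1.4-fold lower number from compound 2 to compound 3 (0.16 log units; within the scatter) both stay within the scatter, as does a 1.2-fold lower number from compound 1 to compound 2 (0.08 log units; within the scatter) at the same place.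

Compound 4 `O=C1C=C(C(O)c2ccoc2)C(=O)c2ccccc21` is still unmeasured. It carries furan-3-yl in place of 4-chlorophenyl on a saturated chain carbon bound to a double-bonded ring carbon and an oxygen on a saturated carbon. Within the data shown here, no compound with furan-3-yl has a value yet, so the only guide is the three exchanges among vinyl, 2-methylprop-1-en-1-yl and 4-chlorophenyl at this place. None of them moved the number beyond the scatter, and no step beyond the scatter is expected in this assay here. The estimated step is a 1.3-fold higher number from compound 3 to compound 4 (0.10 log units; within the scatter) and the direction is only weakly supported. Compound 4 is estimated at 3800 nM (expected range 1900 nM to 7600 nM).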

Compound 4, half-maximal inhibitory concentration: 10900 nM
For compound 4 the middle estimate is 2.9-fold (0.46 log units) below the measured one; the whole stated range lies below it.
By their numbers in this assay, from the lowest: compounds 3, 2 and 1 (each within the scatter of the next); then compound 4.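

In this assay, among these compounds, this position proves less permissive than the earlier compounds suggested: furan-3-yl is the first group here to move the number beyond the scatter, with a 3.6-fold higher number from compound 3 to compound 4 (0.56 log units; beyond the scatter), a 2.5-fold higher number from compound 2 to compound 4 (0.40 log units; beyond the scatter) and a 2.1-fold higher number from compound 1 to compound 4 (0.32 log units; beyond the scatter). All three steps are modest, yet they set compound 4 apart on the weaker side, whereas vinyl, 2-methylprop-1-en-1-yl and 4-chlorophenyl remain within the scatter of one another. No measured evidence on the origin of this difference is available.

As far as these compounds go, with a single furan-3-yl compound, the smaller ring and the ring oxygen cannot be told apart, so thiophen-3-yl and unsubstituted phenyl remain open comparisons. Also open, from the compounds shown here alone, is how an amine or a carboxylic acid on the aryl ring would read in this assay.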